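Trifluoromethyl for Amino: Cytotoxicity Step from Compound 1

A few compounds are considered here, and "the series" means these few. Any claim that something is new, unique, unknown or untested is made for them only; others in the source may bear on it.

Measured so far:
- compound 1, `Cc1cc(NC(=O)Nc2ccc(N)cc2)c2ccccc2n1`: > 25000 nM
- compound 2, `Cc1cc(NC(=O)Nc2ccccc2N)c2ccccc2n1`: > 25000 nM
- compound 3, `Cc1cc(NC(=O)Nc2cccnc2)c2ccccc2n1`: > 25000 nM

In an ADME assay on HEK293 cells (Homo sapiens) for cytotoxicity, with a stated time of 72 h (a lower number here means that less compound is needed, a higher number that more compound is needed for the effect), compound 1 gives > 25000 nM, which is a limit of the assay and not a number. Compound 2 likewise gives only a limit, > 25000 nM. Compound 3 also gives only a limit, > 25000 nM. Among the measured compounds shown here, because of the limit of > 25000 nM in this assay, at which 3 of the 3 values shown sit, none of the measured steps can be read: a step that the two limits leave unreadable from compound 1 to compound 2, a step that the two limits leave unreadable from compound 1 to compound 3 and a step that the two limits leave unreadable from compound 2 to compound 3 all remain without a readable size. Compound 1 thus stands at the limit of this assay, together with the two others shown.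

The compound not yet measured is compound 4, `Cc1cc(NC(=O)Nc2ccc(C(F)(F)F)cc2)c2ccccc2n1`. Its change from compound 1 is trifluoromethyl in place of amino on an aromatic carbon. Two measured steps start from compound 1 and bear on this one, but both were unreadable, so they give no direction and no size to carry over. For the measured compounds named here, the only guide is that all three compounds shown sit at the limit, as the limit of > 25000 nM in this assay, at which 3 of the 3 values shown sit, states. The expected step of a number no higher from compound 1 to compound 4 (the limit leaves the size open) is therefore none beyond the scatter, with the result most likely being a limit again. Compound 4 is estimated at 25000 nM, in a range from 8000 nM to 60000 nM.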

Compound 4, half-maximal effective concentration: 25000 nM
The estimate for compound 4 equals the measured number at the digits printed; the measured number falls inside the stated range.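

In this assay compound 4 gives 25000 nM, the only value among the compounds shown that is a number and not a limit. On this aromatic carbon, para to a large group, the exchange of amino for the larger trifluoromethyl, in which the hydrogen-bond donor and acceptor of amino leave, amounts to a number no higher from compound 1 to compound 4 (the limit leaves the size open). This step fixes a direction no earlier step could give, but its size stays unreadable, as do the steps among the other compounds, and the new number cannot be credited to any property of the group, because most of the values rest on the same limit: the limit of > 25000 nM in this assay, at which 3 of the 4 values shown sit.

The compounds shown leave open whether another group at this place, such as a chlorine atom, a methoxy group or a carboxylic acid, would also give a number and how that number would stand against compound 4. They also leave open whether a longer chain in place of the trifluoromethyl would give a clearly lower number in this assay, or a limit again.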